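Iodo in place of bromo on compound 2

The compounds below may be only part of what the source reports. "The series", "measured", "known", "first", "only" and "open" are said of these compounds alone.

In a functional assay on K562 cells (Homo sapiens) for cytotoxicity, read by XTT assay, with a stated time of 24 h (on this read-out lower numbers stand for stronger inhibition and higher numbers for weaker inhibition), compound 1 `Cc1ccc(NC(=O)c2ccc(Br)cc2OCCCCn2ccnc2)cc1Nc1nccc(-c2cccnc2)n1` gives 66100 nM and compound 2 `Cc1ccc(NC(=O)c2ccc(OCCCCn3ccnc3)c(Br)c2)cc1Nc1nccc(-c2cccnc2)n1` gives 12000 nM as the lower of the two numbers, with a gap beyond the usual scatter. For the measured compounds named here, these two values are the only measurements so far, and the two structures differ in more than one place. Compound 3 `Cc1ccc(NC(=O)c2ccc(OCCCCn3ccnc3)c(I)c2)cc1Nc1nccc(-c2cccnc2)n1` departs from compound 2 in a single place: iodo in place of bromo on an aromatic carbon with iodo in place of bromo on an aromatic carbon, ortho to a 4-(1H-imidazol-1-yl)butoxy group. Going by the values given here, no measured pair shows a change of this kind, so the data give no direct size for it. The expected result in this assay is no shift beyond the scatter and no firm direction, with a 1.2-fold lower number from compound 2 to compound 3 (0.08 log units; within the scatter) as the estimated step. For compound 3 the estimated value is 10000 nM within an expected range from 4500 nM to 24000 nM on this read-out.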

Compound 3, half-maximal inhibitory concentration: 32500 nM
The estimate for compound 3 lay 3.3-fold (0.51 log units) below the measured number; the whole stated range lies below it.
By their numbers in this assay, from the lowest: compound 2; then compound 3; then compound 1.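

In this assay the aromatic carbon ortho to a 4-(1H-imidazol-1-yl)butoxy group does not treat its two halogens alike: iodo in place of bromo gives a 2.7-fold higher number from compound 2 to compound 3 (0.43 log units; beyond the scatter) and so costs a modest amount of inhibition. This is the series' only single-place comparison shown, and the exchange moves the number even though the count of heavy atoms, hydrogen-bond donors and acceptors, rings and net charge stays the same. No measurement here bears on why the two halogens differ.

With only bromo and iodo at this position, the compounds shown give no trend, and chloro, fluoro or a plain hydrogen on the same carbon remain open. Also open, as far as these compounds go, is whether the step would hold with a butoxy chain replaced by a longer chain ending in imidazole.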